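This account rests on a few compounds, and the source may have more. Where it says the series, first, only, none or still open, it means among the compounds named here.

Of the compounds shown here, two of one series have been measured in a functional assay on A549 cells (Homo sapiens) for inhibition, read by MTT assay, with a stated time of 72 h; a higher number here means a weaker inhibitor, a lower number a stronger inhibitor. Compound 1, `O=C1Nc2ccc([N+](=O)[O-])cc2/C1=N/NC(=S)N1CCN(c2ccccc2)CC1`, gives 17900 nM. Compound 2, `Cc1ccc(N2CCN(C(=S)N/N=C3\C(=O)Nc4ccc(Cl)cc43)CC2)cc1`, gives 10100 nM. The gap between the number of compound 2 and the number of compound 1 lies within the scatter of this assay, so the two compounds cannot be told apart on these data.

Compound 3, `O=C1Nc2ccc(Cl)cc2/C1=N/NC(=S)N1CCN(c2ccccc2Cl)CC1`, has not yet been measured in this assay. It differs from compound 2 in one place: 2-chlorophenyl in place of 4-methylphenyl on an amine nitrogen in a ring. Among the measured compounds shown here, no measured pair shows what such a change does to the number, so nothing here points to a step in either direction. Compound 3 is therefore expected to sit close to compound 2, with the step from compound 2 to compound 3 estimated at a 1.0-fold lower number from compound 2 to compound 3 (0.00 log units; within the scatter), which is not beyond the scatter. The number expected for compound 3 in this assay is 10000 nM, with a range from 4000 nM to 30000 nM.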

Compound 3, half-maximal inhibitory concentration: 7920 nM
The estimate for compound 3 lay 1.3-fold (0.10 log units) above the measured number; the measured number falls inside the stated range.
By their numbers in this assay, from the lowest: compounds 3, 2 and 1 (each within the scatter of the next, the first and the last beyond it).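

In this assay, among the compounds shown here, placing 2-chlorophenyl where 4-methylphenyl stood on the amine nitrogen in the ring gives a 1.3-fold lower number from compound 2 to compound 3 (0.11 log units; within the scatter), the first step read at this position. The exchange therefore leaves the number indistinguishable from the scatter, even though the two groups differ in both their substituent and its place on the aromatic ring, so this position accepts this particular change without a measurable effect. No measurement given here bears on this result.

The pair cannot separate the change of methyl to chlorine from the change in where the substituent sits, which 4-chlorophenyl on the same nitrogen would address. It also leaves open whether a cyclohexyl ring, a short alkyl chain, or a phenyl ring carrying an amine or a carboxylic acid would move the number beyond the scatter.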